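Working notes: the step from compound 2 to compound 3

The source may report more compounds than this note shows. Statements on the series, on what has been measured and on what is new or still open speak of the compounds shown alone.

compound 1 `Cc1noc(C)c1-c1cnc(N)c(Oc2ccc(C(=O)Nc3ccccc3)cc2)n1`: 5740 nM
compound 2 `Cc1noc(C)c1-c1cnc(N)c(Oc2ccc(C(=O)Nc3cccc(Cl)c3)cc2)n1`: 1640 nM

Both values come from a functional assay on LoVo cells (Homo sapiens) for inhibition, read by MTT assay, with a stated time of 72 h; a lower number here means a stronger inhibitor, a higher number a weaker inhibitor. Of the two measured compounds, compound 2 has the lower number, 1640 nM. The next structure, compound 3 `Cc1noc(C)c1-c1cnc(N)c(Oc2ccc(C(=O)Nc3ncccc3Cl)cc2)n1`, is not yet measured. The change is 3-chloropyridin-2-yl in place of 3-chlorophenyl on an amide-type nitrogen. Among the compounds with values here, only one measured step bears on it, a 3.5-fold lower number from compound 1 to compound 2 (0.54 log units; beyond the scatter), where chloro took the place of hydrogen on an aromatic carbon. Within the data shown here, compound 3 keeps the chlorine, and no measurement yet covers a swap of this ring, so the support is thin. In this assay, a step no larger than that one is expected, with a higher number somewhat more likely. The expected change is a 1.7-fold higher number from compound 2 to compound 3 (0.23 log units; within the scatter). The estimate for compound 3 is 2800 nM, with an expected range of 800 nM to 8000 nM.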

Compound 3, half-maximal inhibitory concentration: 14800 nM
The estimate for compound 3 lay 5.3-fold (0.72 log units) below the measured number; the measured number lies above the stated range.
By their numbers in this assay, from the lowest: compound 2; then compound 1; then compound 3.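

In this assay, the ring on the amide-type nitrogen proves a sensitive point, and the change from 3-chlorophenyl to 3-chloropyridin-2-yl is costly (a 9.0-fold higher number from compound 2 to compound 3 (0.96 log units; beyond the scatter)). This step is larger than the gain seen on adding chloro (a 3.5-fold lower number from compound 1 to compound 2 (0.54 log units; beyond the scatter)), and keeping the chlorine does not preserve that gain: the comparison with the plain phenyl group also runs towards a higher number (a 2.6-fold higher number from compound 1 to compound 3 (0.41 log units; beyond the scatter)). No measurement at hand accounts for this loss.

The compounds shown do not separate the contribution of the ring nitrogen from that of the chlorine in its new setting, and a plain pyridin-2-yl group on the same amide-type nitrogen would bear directly on this. On these data alone, whether other groups on the phenyl ring, such as methoxy, fluoro or an amine, would improve on compound 2 also remains open.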